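This account rests on a few compounds, and the source may have more. Where it says the series, first, only, none or still open, it means among the compounds named here.

Measured compounds in an ADME assay on HeLa cells (Homo sapiens) for cytotoxicity, read by MTT assay, with a stated time of 72 h; a lower number here means that less compound is tolerated, a higher number that more compound is tolerated:
- compound 1, `Fc1ccccc1/C=N/c1sc2c(c1-c1nc3ccccc3s1)CCC2`: 355 ug/mL
- compound 2, `C(=C/c1ccccc1)\C=N\c1sc2c(c1-c1nc3ccccc3s1)CCC2`: 100 ug/mL
- compound 3, `Clc1ccc(/C=N/c2sc3c(c2-c2nc4ccccc4s2)CCCC3)c(Cl)c1`: 542 ug/mL

Compound 3 gives the highest of the three numbers in this assay, meaning the most compound is tolerated by the cells. Its gap to compound 1 lies within the scatter, so the two cannot be ranked against each other; its gap to compound 2 lies beyond the scatter.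

Compound 4, `C(=C/c1ccccc1)\C=N\c1sc2c(c1-c1nc3ccccc3s1)CCCC2`, differs from compound 3 in one place: 2-phenylethenyl in place of 2,4-dichlorophenyl on a carbon with a double bond to nitrogen. Among the measured compounds shown here, one measured step bears on this. From compound 1 to compound 2 the same kind of exchange, a 2-phenylethenyl group replacing a substituted phenyl group on the carbon double-bonded to nitrogen, gave a 3.6-fold lower number from compound 1 to compound 2 (0.55 log units; beyond the scatter). A step of similar size and direction is therefore expected here, meaning compound 4 should be tolerated less well than compound 3.

For compound 4 the expected value in this assay is 150 ug/mL, with a likely range from 70 ug/mL to 350 ug/mL. For the measured compounds named here, this expected step, a 3.6-fold lower number from compound 3 to compound 4 (0.56 log units; beyond the scatter), rests on the single measured step of a 3.6-fold lower number from compound 1 to compound 2 (0.55 log units; beyond the scatter) only.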

Compound 4, half-maximal cytotoxic concentration: 389 ug/mL
Compound 4: middle estimate off by 2.6-fold (0.41 log units), on the low side; measured number outside the range, above it.
By their numbers in this assay, from the lowest: compound 2; then compounds 1, 4 and 3 (each within the scatter of the next).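

In this assay, a 1.4-fold lower number from compound 3 to compound 4 (0.14 log units; within the scatter), so on the core of compound 3, 2-phenylethenyl and 2,4-dichlorophenyl cannot be told apart when placed on a carbon with a double bond to nitrogen. This exchange therefore does not always bring a step beyond the scatter, as the earlier step did: a 3.6-fold lower number from compound 1 to compound 2 (0.55 log units; beyond the scatter), with a different core and with 2-fluorophenyl as the group replaced. No measurement available here accounts for the difference between these two steps.

It remains open whether the core or the replaced group matters more, as the two steps shown share neither. Also open, going by these compounds, is how this assay responds when an amine, a carboxylic acid or a longer chain sits on that carbon.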